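This account rests on a few compounds, and the source may have more. Where it says the series, first, only, none or still open, it means among the compounds named here.

Compound 3 `COc1ccc(NC(=O)CCC(=O)OCCCCCCSc2ccc([N+](=O)[O-])c3nonc23)cc1` gives 130 nM in an assay on isolated protein for inhibition of glutathione S-transferase Mu 2 (Homo sapiens), with a stated time of 10 min (a higher number here means a weaker inhibitor, a lower number a stronger inhibitor), the lowest of the three numbers measured. Compound 1 `O=C(CCC(=O)OCCCCCCSc1ccc([N+](=O)[O-])c2nonc12)Nc1ccccc1` gives 700 nM in this assay, and compound 2 `O=C(CCC(=O)OCCCCCCSc1ccc([N+](=O)[O-])c2nonc12)Nc1ccc(Br)cc1` gives 32000 nM. Compound 4 `O=C(CCC(=O)OCCCCCCSc1ccc([N+](=O)[O-])c2nonc12)Nc1ccc(C(F)(F)F)cc1` differs from compound 3 in one place: trifluoromethyl in place of methoxy on an aromatic carbon. Within the data shown here, three steps bear on this exchange at the same place. The step of a 5.4-fold lower number from compound 1 to compound 3 (0.73 log units; beyond the scatter) was modest, whereas a 46-fold higher number from compound 1 to compound 2 (1.66 log units; beyond the scatter) was large, and so was a 250-fold lower number from compound 2 to compound 3 (2.39 log units; beyond the scatter). Among the measured compounds shown here, since the only other group placed here, bromo, gave a 46-fold higher number from compound 1 to compound 2 (1.66 log units; beyond the scatter), a large step to a higher number in this assay is expected for trifluoromethyl as well. The step expected is a 38-fold higher number from compound 3 to compound 4 (1.59 log units; beyond the scatter). Compound 4 is therefore estimated at 5000 nM, within a range from 700 nM to 40000 nM.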

Compound 4, half-maximal inhibitory concentration: 90 nM
For compound 4 the middle estimate is 56-fold (1.74 log units) above the measured one, outside the stated range (below it).
By their numbers in this assay, from the lowest: compounds 4 and 3 (each within the scatter of the next); then compound 1; then compound 2.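

In this assay placing trifluoromethyl instead of hydrogen on this aromatic carbon gives a 7.8-fold lower number from compound 1 to compound 4 (0.89 log units; beyond the scatter) and placing it instead of bromo gives a 360-fold lower number from compound 2 to compound 4 (2.55 log units; beyond the scatter) so the high number of compound 2 does not carry over to every group placed here. Trifluoromethyl in place of methoxy gives a 1.4-fold lower number from compound 3 to compound 4 (0.16 log units; within the scatter) and so these two groups cannot be told apart in this assay. No evidence shown explains why bromo stands apart from them. On these data alone, whether chloro, an amine or a carboxylic acid at this place would side with bromo or with methoxy and trifluoromethyl remains open.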